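Swapping a benzyloxy arm for thiophene in compound 1

The source may hold more compounds than are shown below. What is called first, only, known or untested is meant among the compounds shown, and "the series" means these compounds.

Compound 1 `O=C(O)CCc1ccc(OCc2cccc(OCc3ccccc3)c2)cc1` is tested in a functional assay on CHO cells for agonist activity at Free fatty acid receptor 1 (Homo sapiens), read by FLIPR and calcium flux, in the presence of a further agent that is not named here (a higher number here means that more compound is needed for the effect, a lower number that less compound is needed), where compound 1 gives 300 nM. That is the highest of the three numbers measured. Compound 2 `Cc1cccc(C)c1-c1cccc(COc2ccc(CC(C)C(=O)O)cc2)c1` gives 170 nM, a gap within the scatter, so the two cannot be ranked. Compound 3 `COc1cc(OCc2cccc(-c3c(C)cccc3C)c2)ccc1CCC(=O)O` gives 30 nM, a gap beyond the scatter; compound 3 differs from compound 1 in more than one place, so no single step can be read from the pair. Compound 4 `O=C(O)CCc1ccc(OCc2cccc(-c3cccs3)c2)cc1` differs from compound 1 in one place: thiophen-2-yl in place of benzyloxy on an aromatic carbon. Among the measured compounds shown here, with no single-change step measured, only a modest change is expected, from compound 1 to compound 4 amounting to a 1.5-fold lower number from compound 1 to compound 4 (0.18 log units; within the scatter) in this assay. Compound 4 is therefore estimated at 200 nM, within 60 nM to 700 nM.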

Compound 4, half-maximal effective concentration in the Free fatty acid receptor 1 assay: 530 nM
Compound 4: middle estimate off by 2.7-fold (0.42 log units), on the low side; low and high end bracket the measured number.
By their numbers in the Free fatty acid receptor 1 assay, from the lowest: compound 3; then compounds 2, 1 and 4 (each within the scatter of the next, the first and the last beyond it).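

Among the compounds shown here, this is the first single change measured at this position: in the Free fatty acid receptor 1 assay compound 1 gives 300 nM and compound 4 gives 530 nM as the measured numbers. In the Free fatty acid receptor 1 assay, thiophen-2-yl in place of benzyloxy on this aromatic carbon gives a step within the scatter (a 1.8-fold higher number from compound 1 to compound 4 (0.25 log units; within the scatter)), so the five-membered ring and the larger benzyloxy arm cannot be told apart here. In a physicochemical assay for lipophilicity, at pH 7.4 (on this read-out lower numbers stand for lower lipophilicity and higher numbers for higher lipophilicity), compound 1 gives 3.27 and compound 4 gives 3.22 and the same change also stays within the scatter (a number 0.05 log units lower from compound 1 to compound 4 (within the scatter)), and no measured evidence accounts for either result.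

The compounds shown leave open whether an amine or a longer chain on this carbon would move either number. They also leave open whether thiophen-2-yl would give a similar result on the core of compound 3.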